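Series notes: tert-butyl on the amine nitrogen of compound 3

The source may hold more compounds than are shown below. What is called first, only, known or untested is meant among the compounds shown, and "the series" means these compounds.

Compound 3 `CC(C)(NC(=O)CN)C(=O)Nc1nc2ccc(OC(F)(F)F)cc2s1` is one of three compounds run in an ADME assay for pharmacokinetics, read by LC-MS, in simulated gastric fluid, tested at 0.01 mg/mL; on this read-out lower numbers stand for a shorter-lived compound and higher numbers for a longer-lived compound. In this assay compound 3 gives > 4 h, which is a limit of the assay and not a number. Compound 1 `CNCC(=O)N(C)CC(=O)Nc1nc2ccc(OC(F)(F)F)cc2s1` likewise stands at a limit in this assay, with > 4 h. Compound 2 `CCNCC(=O)N(C)CC(=O)Nc1nc2ccc(OC(F)(F)F)cc2s1` also sits at a limit, giving > 4 h in this assay. Compound 3 therefore stands exactly where every measured value stands: the limit of > 4 h in this assay, at which 3 of the 3 values shown sit.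

Compound 4 `CC(C)(C)NCC(=O)NC(C)(C)C(=O)Nc1nc2ccc(OC(F)(F)F)cc2s1` differs from compound 3 by tert-butyl in place of hydrogen on an amine nitrogen. The measured steps that bear on this change are a step that the two limits leave unreadable from compound 1 to compound 2 and a step that the two limits leave unreadable from compound 1 to compound 3; both run between limits, so their sizes cannot be read. With every measured compound at the limit and no readable step, no shift beyond the scatter is expected from compound 3 to compound 4, an expected step that the limit leaves unreadable from compound 3 to compound 4. Compound 4 is accordingly estimated at 6 h in this assay, with a range from 3 h to 12 h, and most probably reported again only as a limit.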

Compound 4, half-life: > 4 h
Compound 4 ended at the assay's limit; the forecaster's own chance of this, stated with the estimate: 85%; the middle value lies beyond the limit too.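

The step from compound 3 to compound 4 cannot be read in this assay: both compounds stand at a limit of the assay, not at a number. The compounds shown leave open how long any of them lasts past that limit, and whether tert-butyl on the amine nitrogen changes the half-life at all.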